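This account rests on a few compounds, and the source may have more. Where it says the series, first, only, none or still open, it means among the compounds named here.

Measured in a functional assay on HCT-15 cells (Homo sapiens) for cytotoxicity, read by ELISA, with a stated time of 4 days; on this read-out higher numbers stand for weaker inhibition and lower numbers for stronger inhibition:
- Compound 1 `Cc1ccsc1-c1cc(-c2ccoc2)cc(-c2ccc(Cl)cc2)n1`: 2990 nM
- Compound 2 `Cc1ccsc1-c1cc(-c2ccc(Cl)o2)cc(-c2ccco2)n1`: 26300 nM

Of these two, compound 2 has the higher number, 26300 nM, and so the weaker inhibition. Its gap to compound 1, at 2990 nM, lies beyond the usual scatter. These two compounds differ in more than one place, so the gap cannot be tied to any single group.

Compound 3 `Cc1ccsc1-c1cc(-c2ccc(Cl)o2)cc(-c2ccc(Cl)cc2)n1` has not yet been measured in this assay. It keeps the 5-chlorofuran-2-yl group of compound 2 and changes one place, where 4-chlorophenyl replaces furan-2-yl: 4-chlorophenyl in place of furan-2-yl on an aromatic carbon. Going by the values given here, no measured pair shows this change alone, so the only guide is indirect. The entering 4-chlorophenyl group already stands in that place in compound 1, which gives 2990 nM. A shift towards stronger inhibition, beyond the scatter, therefore seems likely. The expected change is a 6.6-fold lower number from compound 2 to compound 3 (0.82 log units; beyond the scatter), and this estimate is uncertain. For compound 3, the estimated value is 4000 nM, with an expected range of 1200 nM to 14000 nM.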

Compound 3, half-maximal inhibitory concentration: 30300 nM
For compound 3 the middle estimate is 7.6-fold (0.88 log units) below the measured one, outside the stated range (above it).
By their numbers in this assay, from the lowest: compound 1; then compounds 2 and 3 (each within the scatter of the next).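

In this assay, placing 4-chlorophenyl instead of furan-2-yl on the aromatic carbon next to the ring nitrogen gives a 1.2-fold higher number from compound 2 to compound 3 (0.06 log units; within the scatter), so with 5-chlorofuran-2-yl held in place, the two groups cannot be told apart at this position. The 4-chlorophenyl group therefore does not bring stronger inhibition by itself: with it held fixed, 5-chlorofuran-2-yl in place of furan-3-yl on an aromatic carbon gives a 10-fold higher number from compound 1 to compound 3 (1.01 log units; beyond the scatter), and that step lies beyond the scatter. Among the one-place changes shown, the swap between these two furan groups is thus the only one that moves the number by more than the scatter.

The measurements offer no explanation for either step.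

Going by these compounds, it remains open whether 4-chlorophenyl and furan-2-yl would still match if furan-3-yl stood in the other varied place, since the match rests on a single pair of compounds. The compounds shown also leave open how a non-aromatic group, such as an amine or a longer carbon chain, would behave next to the ring nitrogen.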